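This account rests on a few compounds, and the source may have more. Where it says the series, first, only, none or still open, it means among the compounds named here.

Measured in a functional assay on SN12C cells (Homo sapiens) for inhibition, read by sulforhodamine B assay, with a stated time of 48 h (on this read-out lower numbers stand for stronger inhibition of growth and higher numbers for weaker inhibition of growth), so far:
- compound 1 `Cc1ccc(NC(=O)/C=C/c2ccccc2)c(C(N)=O)c1` gives 9630 nM
- compound 2 `NC(=O)c1cc(Br)ccc1NC(=O)/C=C/c1ccccc1` gives 2960 nM
- compound 3 `NC(=O)c1cc(I)ccc1NC(=O)/C=C/c1ccccc1` gives 635 nM

Compound 3 holds the lowest of the three numbers (635 nM) and is the starting point for the next step. Compound 4 `NC(=O)c1cc(I)ccc1NC(=O)/C=C/c1ccccc1Cl` differs from it by one change, chloro in place of hydrogen on an aromatic carbon (chloro in place of hydrogen on an aromatic carbon, phenyl to 2-chlorophenyl).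

The measured steps bear on this change only loosely. The first, a 3.3-fold lower number from compound 1 to compound 2 (0.51 log units; beyond the scatter), is modest, the second, a 4.7-fold lower number from compound 2 to compound 3 (0.67 log units; beyond the scatter), is also modest, and the third, a 15-fold lower number from compound 1 to compound 3 (1.18 log units; beyond the scatter), is large. All three exchange a group at a single place on the shared core, and none of them touches the phenyl. They show that one atom exchanged on an aromatic carbon can move this series beyond the scatter, but they give no direction for a chloro on the phenyl. No step beyond the scatter is therefore the central expectation, and a modest step either way remains possible. The expected step is a 1.3-fold lower number from compound 3 to compound 4 (0.10 log units; within the scatter) in this assay by this estimate. Compound 4 is estimated at 500 nM (expected range 150 nM to 1700 nM) in this assay on this reasoning.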

Compound 4, concentration for 50% growth inhibition: 1550 nM
Compound 4: middle estimate off by 3.1-fold (0.49 log units), on the low side, and the stated range covers the measured number.
By their numbers in this assay, from the lowest: compound 3; then compounds 4 and 2 (each within the scatter of the next); then compound 1.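

In this assay, the phenyl is now shown to respond to a substituent: 2-chlorophenyl in place of phenyl gives a 2.4-fold higher number from compound 3 to compound 4 (0.39 log units; beyond the scatter). The change therefore weakens growth inhibition, in the opposite direction to the lower numbers seen when bromo and iodo replaced methyl at the other place on the shared core, so an added chloro on an aromatic carbon ortho to a large group is not neutral in this series. No measurement at hand accounts for this step.

As far as these compounds go, it remains open whether this rise is specific to chloro or extends to other groups at this carbon, such as fluoro, methoxy, an amine or a carboxylic acid. From the compounds shown here alone, it is also open whether chloro on another carbon of the phenyl gives a step of the same direction.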